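The source may hold more compounds than are shown below. What is called first, only, known or untested is meant among the compounds shown, and "the series" means these compounds.

In an ADME assay on Vero cells (Chlorocebus sabaeus) for cytotoxicity, read by neutral red uptake, with a stated time of 48 h (a higher number here means a weaker inhibitor, a lower number a stronger inhibitor), compound 1 (`CCCc1cn(Cc2ccccc2O)nn1`) gives > 20000 nM as a limit of the assay. Compound 2 (`CCCCCc1cn(Cc2ccccc2O)nn1`) gives > 20000 nM as a limit too, so it stands without a number. Compound 3 (`CCCCCCCCCCCCCn1cc(COc2ccccc2O)nn1`) likewise gives > 20000 nM as a limit. The set therefore rests on the limit of > 20000 nM in this assay, at which 3 of the 3 values shown sit, and nothing firmer. Compound 4 (`Oc1ccccc1Cn1cc(-c2ccccc2)nn1`) carries phenyl in place of pentyl on an aromatic carbon as its change from compound 2, phenyl in place of pentyl on an aromatic carbon. Within the data shown here, the only measured step, a step that the two limits leave unreadable from compound 1 to compound 2 here, gives no size to carry over, so no step beyond the scatter is expected in this assay and no direction can be argued. The expected step is a step that the limit leaves unreadable from compound 2 to compound 4 on this reading. The estimated value for compound 4 is 25000 nM with 10000 nM to 60000 nM as its expected range.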

Compound 4, half-maximal inhibitory concentration: > 20000 nM
Compound 4 gave a limit, no number; the forecaster's own chance of this, stated with the estimate: 75%; the middle value lies beyond the limit too.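

In this assay compound 4, like compound 1 and compound 2, gives only a limit, so no step among these three can be read. The compounds shown leave open where any of them would fall beyond that limit: the limit of > 20000 nM in this assay, at which 4 of the 4 values shown sit.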